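Estimating the Amino Analogue of Compound 3

The compounds below may be only part of what the source reports. "The series", "measured", "known", "first", "only" and "open" are said of these compounds alone.

Values in an ADME assay on MT4 cells (Homo sapiens) for cytotoxicity, read by MTT assay, with a stated time of 4 days; a higher number here means that more compound is tolerated, a lower number that less compound is tolerated:
- Compound 1 `CC(=O)Nc1ccc2oc(-c3ccccc3)c(O)c(=O)c2c1`: 64700 nM
- Compound 2 `COc1ccccc1-c1oc2ccc(NC(C)=O)cc2c(=O)c1O`: 385000 nM
- Compound 3 `COc1ccc(-c2oc3ccc(NC(C)=O)cc3c(=O)c2O)cc1`: 98700 nM

Compound 3 stands at 98700 nM in this assay. The numbers show a 1.5-fold higher number from compound 1 to compound 3 (0.18 log units; within the scatter), and also a 3.9-fold lower number from compound 2 to compound 3 (0.59 log units; beyond the scatter). Compound 4 `COc1ccc(-c2oc3ccc(N)cc3c(=O)c2O)cc1` has hydrogen in place of acetyl on a nitrogen on an aromatic ring, acetamido to amino (hydrogen in place of acetyl on a nitrogen on an aromatic ring). Going by the values given here, no measured step makes this change. All three steps concern methoxy on an aromatic carbon, reaching a 6.0-fold higher number from compound 1 to compound 2 (0.77 log units; beyond the scatter), so they offer only a loose gauge of size and no direction. The expected outcome is a 1.6-fold lower number from compound 3 to compound 4 (0.22 log units; within the scatter), with no step beyond the scatter anticipated. Compound 4 is estimated at 60000 nM, with an expected range from 20000 nM to 180000 nM.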

Compound 4, half-maximal cytotoxic concentration: 239000 nM
Estimate against measurement, compound 4: 4.0-fold (0.60 log units) below; the whole stated range lies below it.
By their numbers in this assay, from the lowest: compounds 1 and 3 (each within the scatter of the next); then compounds 4 and 2 (each within the scatter of the next).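

In this assay, the nitrogen on the aromatic ring proves to be a place where the number can move: hydrogen in place of acetyl gives a 2.4-fold higher number from compound 3 to compound 4 (0.38 log units; beyond the scatter). Going by these compounds alone, the earlier compounds changed only the methoxy on the aromatic carbon, so this is the first direction seen for this change, and it rests on a single pair. No measurement here accounts for the rise.

On these data alone, whether the same change holds on the cores of compound 1 and compound 2 remains open. So does the outcome with a methyl group or a longer acyl chain, such as propionyl, on this nitrogen.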